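A few compounds are considered here, and "the series" means these few. Any claim that something is new, unique, unknown or untested is made for them only; others in the source may bear on it.

Compound 1 `COc1ccc([C@@H]2CC(=O)c3c(O)cc(OCc4cn(Cc5ccccc5C(F)(F)F)nn4)cc3O2)cc1O` is the starting point of this account. In a functional assay on RAW264.7 cells (Mus musculus) for inhibition, read by Griess assay, with stated times of 2 h and 24 h (a lower number here means a stronger inhibitor, a higher number a weaker inhibitor), compound 1 gives 12500 nM, which is the highest of the three numbers recorded, although every other measured compound sits within the usual scatter of it. Compound 2 `COc1ccc([C@@H]2CC(=O)c3c(O)cc(OCc4cn(CC5CC5)nn4)cc3O2)cc1O` gives 11900 nM in this assay, and compound 3 `COc1ccc([C@@H]2C/C(=N\O)c3c(O)cc(OCc4cn(C5CCCC5)nn4)cc3O2)cc1O` gives 6880 nM in this assay; compound 3 also differs from compound 1 in two places, so its number is noted only for orientation. Among the measured compounds shown here, the one measured step that changes a single place is a 1.1-fold lower number from compound 1 to compound 2 (0.02 log units; within the scatter), where cyclopropyl stands in place of 2-(trifluoromethyl)phenyl on a saturated chain carbon bound to an aromatic nitrogen, and the number did not move beyond the scatter.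

Compound 4 `COc1ccc([C@@H]2CC(=O)c3c(O)cc(OCc4cn(Cc5ccc(F)cc5)nn4)cc3O2)cc1O` alters the same position of compound 1: 4-fluorophenyl in place of 2-(trifluoromethyl)phenyl on a saturated chain carbon bound to an aromatic nitrogen. The only step that bears on this, a 1.1-fold lower number from compound 1 to compound 2 (0.02 log units; within the scatter), was flat, and a second aryl group at this position gives no reason on the data shown to expect otherwise. The step from compound 1 to compound 4 is therefore expected to be a 1.0-fold lower number from compound 1 to compound 4 (0.02 log units; within the scatter), within the scatter. Compound 4 is expected to give about 12000 nM in this assay, with a likely range from 6000 nM to 24000 nM.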

Compound 4, half-maximal inhibitory concentration: 15100 nM
Compound 4: the middle estimate sits 1.3-fold (0.10 log units) below what was measured, and the stated range covers the measured number.
By their numbers in this assay, from the lowest: compounds 3, 2, 1 and 4 (each within the scatter of the next, the first and the last beyond it).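

In this assay, the exchange of 2-(trifluoromethyl)benzyl for 4-fluorobenzyl on the shared core leaves the number within the scatter (a 1.2-fold higher number from compound 1 to compound 4 (0.08 log units; within the scatter)), so this position has now tolerated a second aryl group as well as the earlier cyclopropyl. The direct comparison of those two replacements is also within the scatter (a 1.3-fold higher number from compound 2 to compound 4 (0.10 log units; within the scatter)), which means that 2-(trifluoromethyl)phenyl, 4-fluorophenyl and cyclopropyl, on a saturated chain carbon bound to an aromatic nitrogen, cannot be told apart by this read-out, although the groups that leave and enter differ in heavy-atom count and in the fluorine they carry. No independent measurement is available to account for this flat response.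

These three groups do not show whether the position stays equally flat when it carries a group of a different kind, such as an amine or a carboxylic acid, in place of the aryl and cyclopropyl groups. On these data alone, compound 3 differs from compound 1 in two places, so what each of its changes contributes on its own also remains open.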